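Series notes: chloro for methoxy on the pendant phenyl

A few compounds are considered here, and "the series" means these few. Any claim that something is new, unique, unknown or untested is made for them only; others in the source may bear on it.

Measured so far:
- Compound 1 `COc1ccc(C2SCC(=O)N2n2c(CSc3nnc(-c4ccncc4)o3)nc3ccccc3c2=O)cc1` gives 33.8% in a functional assay on the whole organism (strain Charles-Foster albino) for inhibition, with Rattus norvegicus as the target, read by paw edema, at a dose of 50 mg/kg by the oral route; on this read-out higher numbers stand for more inhibition at the one dose given (going by the name of the read-out) and lower numbers for less inhibition.
- Compound 2 `COc1ccc(C2SCC(=O)N2n2c(CSc3nnc(-c4ccncc4)o3)nc3ccc(Br)cc3c2=O)cc1` gives 35.3% in this assay.

For the measured compounds named here, compound 2 holds the higher of the two numbers, but its only neighbour is compound 1, and the step of a number 1.5 percentage points higher from compound 1 to compound 2 (within the scatter) lies within the scatter, so the two compounds cannot be placed in order on this read-out.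

Compound 3 `O=C1CSC(c2ccc(Cl)cc2)N1n1c(CSc2nnc(-c3ccncc3)o2)nc2ccc(Br)cc2c1=O` is the next entry. Relative to compound 2 the change is chloro in place of methoxy on an aromatic carbon.

Going by the values given here, the one measured step, bromo in place of hydrogen on the core, concerns another place and other groups, and there is no measured pair that exchanges methoxy for chloro or alters the 4-methoxyphenyl at all. Among the compounds with values here, no measured step therefore bears on this change. With no guide from the data, the expectation for compound 3 is no step beyond the scatter from compound 2, that is, an expected a number 0.3 percentage points lower from compound 2 to compound 3 (within the scatter) in this assay.

Compound 3 is accordingly estimated at 35%, with a range from 24% to 46%.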

Compound 3, a percentage reported as inhibition, in the whole organism at one dose (the size of the read-out at that dose, not a potency): 25.2%
The estimate for compound 3 lay 9.8 percentage points above the measured number; the measured number falls inside the stated range.
By their numbers in this assay, from the lowest: compounds 3, 1 and 2 (each within the scatter of the next, the first and the last beyond it).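

Working notes: in this assay the change from 4-methoxyphenyl to 4-chlorophenyl gives a number 10.1 percentage points lower from compound 2 to compound 3 (beyond the scatter) and is the first step in the series that clears the scatter. For the compounds shown here, the group on the pendant phenyl, para to a large group, therefore has a readable bearing on this read-out, whereas the one earlier change, bromo in place of hydrogen on the core, gave a number 1.5 percentage points higher from compound 1 to compound 2 (within the scatter) and could not be read. This rests on a single pair with bromo on the core and a modest step, and nothing available on these compounds accounts for the lower number.

Open, as far as these compounds go, is whether the same exchange of methoxy for chloro gives a step of similar size when the core carries hydrogen instead of bromo, since the series shows this exchange only with bromo present. Also open, from the compounds shown here alone, is how the plain phenyl, or a phenyl carrying a fluoro, hydroxy, dimethylamino or carboxylic acid group at the same place, would stand against the 4-methoxyphenyl and 4-chlorophenyl compounds, which would show whether methoxy or chloro is the group that departs from the parent level.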